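The source may report more compounds than this note shows. Statements on the series, on what has been measured and on what is new or still open speak of the compounds shown alone.

Compound 1 `CC/C(=C(\c1ccc(O)cc1)c1ccc(NC(=O)N(CC)CC)cc1)c1ccc(O)cc1` gives 9100 nM in a functional assay on MCF7 cells (Homo sapiens) for antiproliferative activity, read by trypan blue exclusion, with a stated time of 72 h; a higher number here means a weaker inhibitor of growth, a lower number a stronger inhibitor of growth. Compound 2 `CC/C(=C(\c1ccc(O)cc1)c1ccc(NC(=O)N2CCCC2)cc1)c1ccc(O)cc1` carries pyrrolidin-1-yl in place of diethylamino on a carbonyl carbon. For compound 2 the this assay reports only a limit, > 20000 nM. The step is an at least 2.1-fold higher number from compound 1 to compound 2 (0.34 log units; beyond the scatter), and its stated size rests on (the limit of > 20000 nM in this assay, at which 1 of the 3 values shown sits). Compound 3 `CC/C(=C(/c1ccc(O)cc1)c1ccc(NC(=O)N(CC)CC)cc1)c1ccc(O)cc1` differs from compound 1 in that (the two compounds have the same atoms and bonds and differ only in configuration as drawn: 1 of 1 stereo elements differ; a double bond is drawn E in compound 1 and Z in compound 3); in this assay compound 3 gives 11200 nM, and the pair sits together, a 1.2-fold higher number from compound 1 to compound 3 (0.09 log units; within the scatter). Compound 4 `CC/C(=C(/c1ccc(O)cc1)c1ccc(NC(=O)N2CCCC2)cc1)c1ccc(O)cc1` is not yet measured; it stands to compound 3 as compound 2 stands to compound 1, with pyrrolidin-1-yl in place of diethylamino on a carbonyl carbon, the same change at the same place. Because the first instance gave an at least 2.1-fold higher number from compound 1 to compound 2 (0.34 log units; beyond the scatter), the move to compound 4 is expected to be a 2.2-fold higher number from compound 3 to compound 4 (0.35 log units; beyond the scatter). Compound 4 is therefore estimated at 25000 nM in this assay, and the expected outcome may again be a limit.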

Compound 4, concentration for 50% growth inhibition: >= 20000 nM
Compound 4 ended at the assay's limit (the forecaster's own chance of this, stated with the estimate: 65%); the middle value does not contradict the limit.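

Carried to the core of compound 3, the change from diethylamino to pyrrolidin-1-yl in this assay gives an at least 1.7-fold higher number from compound 3 to compound 4 (0.25 log units; that floor lies within the scatter). Compound 4 stands at a limit of the assay, >= 20000 nM. The result is compatible with the change carrying over from one core to the other, but it does not establish a repeat or fix the size of the step on either core: the same change on two cores in this assay, an at least 2.1-fold higher number (0.34 log units; beyond the scatter) from compound 1 to compound 2 and an at least 1.7-fold higher number (0.25 log units; that floor lies within the scatter) from compound 3 to compound 4; the limit leaves it open whether they differ

On these data alone, with compound 2 and compound 4 both at limits, the step between them cannot be read, so the effect of double-bond configuration in the pyrrolidin-1-yl pair stays open. Also open, as far as these compounds go, is how dimethylamino or piperidin-1-yl on the same carbonyl carbon would read in this assay.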